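A few compounds are considered here, and "the series" means these few. Any claim that something is new, unique, unknown or untested is made for them only; others in the source may bear on it.

In a functional assay on HeLa cells (Homo sapiens) for cytotoxicity, read by ELISA, with a stated time of 4 days (on this read-out higher numbers stand for weaker inhibition and lower numbers for stronger inhibition), compound 1 `Cc1ccsc1-c1cc(-c2ccoc2)cc(-c2ccc(Cl)cc2)n1` gives 17400 nM and compound 2 `Cc1ccccc1-c1cc(-c2ccoc2)cc(-c2ccc(Cl)s2)n1` gives 19000 nM so the two values lie within the scatter of each other and compound 2 holds no separate rank. Within the data shown here, compound 1 and compound 2 differ in more than one place, so no measured step isolates a single change. Compound 3 `Clc1ccc(-c2cc(-c3ccoc3)cc(-c3ccccn3)n2)s1` differs from compound 2 by pyridin-2-yl in place of 2-methylphenyl on an aromatic carbon with pyridin-2-yl in place of 2-methylphenyl on an aromatic carbon next to the ring nitrogen. Among the measured compounds shown here, no measured pair tests this replacement, so the expectation is loose: a modest shift toward stronger inhibition, near the edge of the scatter. The expected change in this assay is a 1.7-fold lower number from compound 2 to compound 3 (0.24 log units; within the scatter) on this estimate. Compound 3 is estimated at 11000 nM with an expected range from 3500 nM to 30000 nM in the same read-out.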

Compound 3, half-maximal inhibitory concentration: 21600 nM
Compound 3: middle estimate off by 2.0-fold (0.29 log units), on the low side; low and high end bracket the measured number.
By their numbers in this assay, from the lowest: compounds 1, 2 and 3 (each within the scatter of the next).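

In this assay, among these compounds, pyridin-2-yl in place of 2-methylphenyl on the aromatic carbon next to the ring nitrogen gives a 1.1-fold higher number from compound 2 to compound 3 (0.06 log units; within the scatter), the first single-place comparison, and the two numbers cannot be told apart. At this position, with 5-chlorothiophen-2-yl and furan-3-yl held constant, a ring of carbon only with 0 hydrogen-bond acceptors and a ring with 1 hetero atom and 1 hydrogen-bond acceptor give values within the scatter of each other. No measurement at hand accounts for this result.

The step exchanges the methyl group and the ring nitrogen together, so neither is read alone, and a plain phenyl at this place would separate them. From the compounds shown here alone, how a carboxylic acid, an aminomethyl group or a longer chain on this ring would read out remains open.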